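The source may report more compounds than this note shows. Statements on the series, on what has been measured and on what is new or still open speak of the compounds shown alone.

Working notes on the series. Two compounds carry measurements so far. In a functional assay on Right cardiac atrium for agonist activity at histamine H2 receptor (Cavia porcellus), with a stated time of 30 min, in the presence of a further agent that is not named here (a lower number here means that less compound is needed, a higher number that more compound is needed for the effect), compound 1 `Cc1nc(N)sc1CCCN/C(N)=N/C(=O)NC(C)c1ccc(Br)cc1` gives 55 nM. Compound 2 `Cc1nc(N)sc1CCCN/C(N)=N/C(=O)N[C@@H](C)c1ccccc1` gives 23.4 nM in this assay. Compound 1 therefore holds the higher of the two numbers, and the gap down to compound 2 lies beyond the usual scatter; the two structures differ in more than one place, so nothing beyond those two values can be read from the pair.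

Compound 3 `Cc1nc(N)sc1CCCN/C(N)=N/C(=O)NC(C)c1ccc(Cl)cc1` is the next entry. It differs from compound 1 by chloro in place of bromo on an aromatic carbon; the same difference, cut one bond further out, reads 4-bromophenyl to 4-chlorophenyl. Among the measured compounds shown here, no measured pair in the set isolates this exchange, so the numbers in hand do not fix its size. The exchange is expected to give a 1.1-fold lower number from compound 1 to compound 3 (0.04 log units; within the scatter), a step of a size not beyond the scatter, in either direction. Compound 3 is accordingly estimated at 50 nM in this assay, with a range from 20 nM to 130 nM.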

Compound 3, half-maximal effective concentration: 24.6 nM
Estimate against measurement, compound 3: 2.0-fold (0.31 log units) above, within the range that was stated.
By their numbers in this assay, from the lowest: compounds 2 and 3 (each within the scatter of the next); then compound 1.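

Among the compounds shown here, the exchange of chloro in place of bromo, on an aromatic carbon para to a large group, gives in this assay a 2.2-fold lower number from compound 1 to compound 3 (0.35 log units; beyond the scatter) and is the first single-place change. This position therefore responds measurably to the exchange of one halogen for another, which the earlier pair, differing in more than one place, could not show. No measured property of either group is available to account for the step.

The compounds shown leave open how fluoro, methoxy or trifluoromethyl in the same place would compare with chloro and bromo. One pair also cannot show whether this step would keep its size and direction if the exchange were made on a different core, for example one with a longer chain.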